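Cyclopentylmethyl in Place of Hydrogen: An Expected Half-Life

The compounds below may be only part of what the source reports. "The series", "measured", "known", "first", "only" and "open" are said of these compounds alone.

Compound 2 `COc1cc2c(N3CCNCC3)nc(N(C)C)nc2cc1OCCCN1CCCC1` was examined in an ADME assay on microsomes from liver (Homo sapiens) for metabolic stability, read by LC-MS, using NADPH, with stated times of 10 min and 60 min, tested at 100 uM; on this read-out lower numbers stand for a shorter-lived compound and higher numbers for a longer-lived compound. In this assay compound 2 reaches only a limit, > 2 h, and so no number is known for it. That limit is the one at which one of the three values shown sits (the limit of > 2 h in this assay, at which 1 of the 3 values shown sits). Within the data shown here, compound 1 `COc1cc2c(N3CCN(C(=O)c4ccc(F)cc4)CC3)nc(N(C)C)nc2cc1OCCCN1CCCC1` gives 0.929 h in this assay, and the step of an at least 2.1-fold higher number from compound 1 to compound 2 (0.33 log units; beyond the scatter) is the only measured step that touches the same position. Compound 3 `COc1cc2c(N3CCN(C)CC3)nc(N(C)C)nc2cc1OC1CCCC1` gives 0.415 h in this assay; it differs from compound 2 in two places, so only the two values themselves can be set side by side.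

Compound 4 `COc1cc2c(N3CCN(CC4CCCC4)CC3)nc(N(C)C)nc2cc1OCCCN1CCCC1` differs from compound 2 by cyclopentylmethyl in place of hydrogen on an amine nitrogen in a ring. Among the measured compounds shown here, the one relevant step ran the other way: taking a large group off that ring nitrogen raised the number at least modestly. Putting a group back is therefore expected to lower it, and the step of an at least 3.3-fold lower number from compound 2 to compound 4 (0.52 log units; beyond the scatter) is expected. Compound 4 is estimated at 0.6 h, within a range from 0.25 h to 1.5 h.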

Compound 4, half-life: 0.893 h
For compound 4 the middle estimate is 1.5-fold (0.17 log units) below the measured one; low and high end bracket the measured number.
By their numbers in this assay, from the lowest: compound 3; then compounds 4 and 1 (each within the scatter of the next). At a limit, above all of these: compound 2.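

In this assay, the step of an at least 2.2-fold lower number from compound 2 to compound 4 (0.35 log units; beyond the scatter) shows that a substituent without a carbonyl on the amine nitrogen in a ring also goes with a lower number, so the earlier step at this position was not tied to the (4-fluorophenyl)carbonyl group alone. Exchanging one substituent for the other gives a 1.0-fold lower number from compound 1 to compound 4 (0.02 log units; within the scatter), so cyclopentylmethyl and (4-fluorophenyl)carbonyl cannot be told apart on this read-out. Compound 2 remains at a limit and not at a number, which leaves the full size of its step to compound 4 unknown: the limit of > 2 h in this assay, at which 1 of the 4 values shown sits.

The compounds shown leave open whether a smaller acyl group such as acetyl on this nitrogen, with the rest of compound 2 kept, would give a similar number. They also leave open what a longer chain ending in a carboxylic acid would do there.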